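The compounds below may be only part of what the source reports. "The series", "measured", "known", "first", "only" and "open" are said of these compounds alone.

Measured compounds:
- Compound 1 `COc1ccc(OC)c(COc2cc(NC(=O)c3ccc(OC)c(OC)c3)ccc2N(C)S(C)(=O)=O)c1`, which in a functional assay on SK-BR-3 cells (Homo sapiens) for antiproliferative activity, read by MTT assay, with a stated time of 48 h (a lower number here means a stronger inhibitor, a higher number a weaker inhibitor), gives 2.61 nM.
- Compound 2 `COc1ccc(OC)c(COc2cc(NC(=O)c3ccc(I)cc3)ccc2N(C)S(C)(=O)=O)c1`, which in this assay gives 1.21 nM.
- Compound 3 `COc1ccc(OC)c(COc2cc(NC(=O)c3ccc(OC)c(OC)c3)ccc2NS(C)(=O)=O)c1`, which in this assay gives 11 nM.

Compound 2 differs from compound 1 only in the group on the carbonyl carbon: 4-iodophenyl in place of 3,4-dimethoxyphenyl on a carbonyl carbon. That change gave a 2.2-fold lower number from compound 1 to compound 2 (0.33 log units; beyond the scatter). Compound 3 differs from compound 1 in the core, at the sulfonamide nitrogen: hydrogen in place of methyl on a sulfonamide nitrogen, which gave a 4.2-fold higher number from compound 1 to compound 3 (0.62 log units; beyond the scatter).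

Compound 4 `COc1ccc(OC)c(COc2cc(NC(=O)c3ccc(I)cc3)ccc2NS(C)(=O)=O)c1` has not yet been measured. It stands to compound 3 as compound 2 stands to compound 1, the change being (4-iodophenyl in place of 3,4-dimethoxyphenyl on a carbonyl carbon), and the place of the change is described in the same words for both pairs, so it is the same change, made on the core of compound 3 instead of the core of compound 1.

For the measured compounds named here, the expectation for compound 4 rests on the one earlier instance of this change, where compound 1 to compound 2 gave a 2.2-fold lower number from compound 1 to compound 2 (0.33 log units; beyond the scatter). Compound 4 is therefore expected to show a 2.2-fold lower number from compound 3 to compound 4 (0.34 log units; beyond the scatter), a step similar in size to the earlier one. The estimate for compound 4 is 5 nM, most likely lying between 2.5 nM and 12 nM.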

Compound 4, half-maximal inhibitory concentration: 11.8 nM
For compound 4 the middle estimate is 2.4-fold (0.37 log units) below the measured one, and the stated range covers the measured number.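

In this assay, 4-iodophenyl in place of 3,4-dimethoxyphenyl on the carbonyl carbon gave a 1.1-fold higher number from compound 3 to compound 4 (0.03 log units; within the scatter), and the two steps for this change on the two cores do not differ beyond the scatter: the same change on two cores in this assay, a 2.2-fold lower number (0.33 log units; beyond the scatter) from compound 1 to compound 2 and a 1.1-fold higher number (0.03 log units; within the scatter) from compound 3 to compound 4, 2.3-fold (0.36 log units) apart, within the scatter of two such steps. Hydrogen in place of methyl on the sulfonamide nitrogen gave a 9.8-fold higher number from compound 2 to compound 4 (0.99 log units; beyond the scatter), and this change also carries over between the two cores within the scatter: the same change on two cores in this assay, a 4.2-fold higher number (0.62 log units; beyond the scatter) from compound 1 to compound 3 and a 9.8-fold higher number (0.99 log units; beyond the scatter) from compound 2 to compound 4, 2.3-fold (0.36 log units) apart, within the scatter of two such steps. These four compounds therefore show no dependence of either change on the core, but they do not show that the aryl change has a real effect on the core of compound 3, where its step lies within the scatter, nor that the agreement extends to other cores or other assays.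

On these data alone, it remains open whether an ethyl group on the sulfonamide nitrogen would fall in line with methyl or with hydrogen. As far as these compounds go, it also remains open whether a pyridine ring or a cyclohexyl group on the carbonyl carbon would carry over between these two cores in the same way.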